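The compounds below may be only part of what the source reports. "The series", "measured", "known", "first", "only" and "open" are said of these compounds alone.

Measured compounds:
compound 1 `COC1=CC(=O)c2c(c(COC(=O)c3ccc(F)cc3)cn2C)C1=O`: 50 nM
compound 2 `COC1=CC(=O)c2c(c(COC(=O)c3ccccc3)cn2C)C1=O`: 40 nM
compound 3 `COC1=CC(=O)c2c(c(COc3ccccc3)c(C)n2C)C1=O`: 700 nM

In a functional assay on V79-379A cells (Cricetulus griseus) for cytotoxicity, read by MTT assay, in the presence of a further agent that is not named here (on this read-out higher numbers stand for weaker inhibition and lower numbers for stronger inhibition), compound 2 gives 40 nM and compound 1 gives 50 nM. The difference between them is fluoro in place of hydrogen on an aromatic carbon, and the step was a 1.3-fold higher number from compound 2 to compound 1 (0.10 log units; within the scatter). Compound 3 `COC1=CC(=O)c2c(c(COc3ccccc3)c(C)n2C)C1=O` has a different core; the difference between the two cores is not broken down here. In this assay compound 3 gives 700 nM, the highest number of the three. Compound 4 `COC1=CC(=O)c2c(c(COc3ccc(F)cc3)c(C)n2C)C1=O` is not yet measured. It differs from compound 3 by fluoro in place of hydrogen on an aromatic carbon, the same change as from compound 2 to compound 1. Because that earlier step was a 1.3-fold higher number from compound 2 to compound 1 (0.10 log units; within the scatter), the expected step here is a 1.1-fold higher number from compound 3 to compound 4 (0.06 log units; within the scatter), though the core is different. For compound 4 the estimate in this assay is 800 nM, between 350 nM and 1800 nM.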

Compound 4, half-maximal inhibitory concentration: 850 nM
The estimate for compound 4 lay 1.1-fold (0.03 log units) below the measured number, and the stated range covers the measured number.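

In this assay, replacing phenoxy with 4-fluorophenoxy gave a 1.2-fold higher number from compound 3 to compound 4 (0.08 log units; within the scatter), so the two compounds cannot be told apart. Set side by side, the two steps agree: the same change on two cores in this assay, a 1.3-fold higher number (0.10 log units; within the scatter) from compound 2 to compound 1 and a 1.2-fold higher number (0.08 log units; within the scatter) from compound 3 to compound 4, 1.0-fold (0.01 log units) apart, within the scatter of two such steps On these two cores, then, fluoro in place of hydrogen stays within the scatter, but two pairs cannot show that this would hold on other cores, and they do not explain why.

The compounds shown leave open what other groups on that same aromatic carbon would do, such as chloro, methoxy or an amine. They also leave open which of the differences between the two cores accounts for the gap in their numbers.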